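Adding a Methoxy Group: Does the Weakening Step Repeat?

This account rests on a few compounds, and the source may have more. Where it says the series, first, only, none or still open, it means among the compounds named here.

Of the compounds shown here, three in this set have been tested in a functional assay on T47D cells (Homo sapiens) for cytotoxicity, read by sulforhodamine B assay, with a stated time of 48 h, tested at 1 uM; a higher number here means a weaker effect of the compound at the concentration tested, a lower number a stronger effect. Compound 1 `COc1ccc(-c2cc(/C=C/C(=O)c3ccc(N)cc3)[nH]n2)cc1` gives 60%. Compound 3 `COc1ccc(-c2cc(/C=C/C(=O)c3ccc(N)cc3)[nH]n2)cc1OC` gives 87%. The two differ in one place, (methoxy in place of hydrogen on an aromatic carbon), and the measured step is a number 27 percentage points higher from compound 1 to compound 3 (beyond the scatter), so adding the methoxy group here made the compound act less strongly on the cells.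

Compound 2 `COc1ccc(C(=O)/C=C/c2cc(-c3cc(OC)c(OC)c(OC)c3)n[nH]2)cc1OC` is built on a different core; the difference between the two cores is not broken down here. In this assay compound 2 gives 75%, which stands between the numbers for compound 1 and compound 3.

Compound 4 `COc1cc(C(=O)/C=C/c2cc(-c3cc(OC)c(OC)c(OC)c3)n[nH]2)cc(OC)c1OC` has not yet been measured. It is related to compound 2 by methoxy in place of hydrogen on an aromatic carbon. Among the compounds with values here, this is the same kind of change as the one from compound 1 to compound 3, not the same change: in compound 4 the new methoxy group is also meta to a methoxy group, a surrounding that compound 3 does not have, and the core is a different one.

If the change behaves as it did before, compound 4 is expected to act less strongly than compound 2, and the step expected in this assay is a number 15 percentage points higher from compound 2 to compound 4 (beyond the scatter), set somewhat smaller than the earlier step because compound 2 already starts at 75% and the read-out cannot rise far above full activity. The estimate for compound 4 is 90%, expected to lie between 75% and 100%.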

Compound 4, a percentage reported as activity, at one concentration (the size of the read-out at that concentration, not a potency): 57%
Compound 4: the middle estimate sits 33 percentage points above what was measured, outside the stated range (below it).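

In this assay the weakening seen earlier did not repeat: the added methoxy group gave a number 18 percentage points lower from compound 2 to compound 4 (beyond the scatter), so here the compound acted more strongly on the cells, not less. Set side by side, the two steps run in opposite directions, and the gap between them is larger than chance scatter would explain: the same change on two cores in this assay, a number 27 percentage points higher (beyond the scatter) from compound 1 to compound 3 and a number 18 percentage points lower (beyond the scatter) from compound 2 to compound 4, 45 percentage points apart, beyond the scatter of two such steps. Within the data shown here, this shows that the effect of adding a methoxy group cannot be carried from one core to the other, but it does not show what sets the direction, as each core offers only one pair, and the pairs differ both in the core and in the surroundings of the new group, which in compound 4 is meta to a methoxy group.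

The compounds shown leave open whether the reversal comes from the core or from those surroundings, which a methoxy group added to each core at a matching place could help separate. They also leave open how a hydroxyl group, a fluorine atom or an ethoxy group at the same place on compound 2 would compare with the methoxy group of compound 4.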